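Swapping a nitrile for a methoxy group on the sulfonyl-bearing ring

A few compounds are considered here, and "the series" means these few. Any claim that something is new, unique, unknown or untested is made for them only; others in the source may bear on it.

Measured compounds:
- compound 1, `CC(O)(C(=O)Nc1ccc(S(=O)(=O)c2ccccc2)c(C#N)c1)C(F)(F)F`: 3800 nM
- compound 2, `CC(O)(C(=O)Nc1ccc(S(=O)(=O)c2ccccc2C#N)cc1)C(F)(F)F`: 1100 nM
- compound 3, `CC(O)(C(=O)Nc1ccc(S(=O)(=O)c2ccccc2)c(O)c1)C(F)(F)F`: 430 nM

All three share one core and were tested in a functional assay (Cavia porcellus) with sulfonylurea receptors; K-ATP channels (Homo sapiens) as the target; on this read-out higher numbers stand for weaker inhibition and lower numbers for stronger inhibition. Compound 2 stands second highest of the three numbers: compound 3 gives 430 nM, a lower number beyond the scatter, while compound 1 gives 3800 nM, a higher number beyond the scatter.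

The new compound 4, `COc1ccccc1S(=O)(=O)c1ccc(NC(=O)C(C)(O)C(F)(F)F)cc1`, differs from compound 2 in one place: methoxy in place of cyano on an aromatic carbon.

Going by the values given here, the only measured step that changes a cyano group is an 8.8-fold lower number from compound 1 to compound 3 (0.95 log units; beyond the scatter), but that swap put in a hydroxy group and sat on the other ring, ortho to a large group in a different sense, so it bears on the present step only loosely. Among the compounds with values here, no measured pair compares cyano with methoxy. The expected step is therefore small and of uncertain direction, most likely within the scatter, so the estimate is a 1.2-fold lower number from compound 2 to compound 4 (0.09 log units; within the scatter) in this assay.

Compound 4 is thus expected to give about 900 nM in this assay, with a likely range from 300 nM to 3000 nM.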

Compound 4, half-maximal inhibitory concentration: 1600 nM
Compound 4: middle estimate off by 1.8-fold (0.25 log units), on the low side; the measured number falls inside the stated range.
By their numbers in this assay, from the lowest: compound 3; then compounds 2 and 4 (each within the scatter of the next); then compound 1.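

Going by these compounds alone, on the change from 2-cyanophenyl to 2-methoxyphenyl, the step in this assay is a 1.5-fold higher number from compound 2 to compound 4 (0.16 log units; within the scatter) and gives the first direct comparison of these two groups on an aromatic carbon ortho to a large group. At this place, the two groups cannot be told apart on this read-out, whereas replacing cyano with hydroxy at a different place gave an 8.8-fold lower number from compound 1 to compound 3 (0.95 log units; beyond the scatter). No measurement is available that would explain the result.

The compounds shown leave open whether an amine or a carboxylic acid at this place would shift the number beyond the scatter. They also leave open whether a hydroxy group or a longer chain such as ethoxy here would separate from the cyano and methoxy groups.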